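Pyridin-2-yl for pyrimidin-2-yl in a highly bound pair

The compounds below may be only part of what the source reports. "The series", "measured", "known", "first", "only" and "open" are said of these compounds alone.

In an ADME assay on a cell-free system (plasma, Mus musculus) for protein binding, read by LC-MS, using ultracentrifugation, with a stated time of 4.2 h, tested at 1000 ng/mL, compound 1 `O=C(NNS(=O)(=O)c1ccccc1F)c1cc(F)cc(-n2cccn2)c1` gives 98.9% and compound 2 `Cc1cc(-c2ncccn2)cc(C(=O)NNS(=O)(=O)c2ccccc2)c1F` gives 99.4%. These two values lie within the scatter of each other, so compound 2 stands level with compound 1, and both are almost entirely bound. Compound 3 `Cc1cc(-c2ccccn2)cc(C(=O)NNS(=O)(=O)c2ccccc2)c1F` has not yet been measured. It carries pyridin-2-yl in place of pyrimidin-2-yl on an aromatic carbon of compound 2 (pyridin-2-yl in place of pyrimidin-2-yl on an aromatic carbon). The swapped group sits para to a fluoro group and meta to a methyl group. Going by the values given here, no measured pair isolates this swap in this assay. A step beyond the scatter is therefore not expected, only a slight drift towards more binding, if any. The expected step is a 1.2-fold lower unbound fraction from compound 2 to compound 3 (0.08 log units; within the scatter). For compound 3 the estimated value is 99.5%, with an expected range of 98.9% to 99.8%.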

Compound 3, plasma protein binding in the Mus musculus assay: 99.9%
Estimate against measurement, compound 3: 5.0-fold (0.70 log units) (unbound fraction) above, and the stated range ends below it.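

At this position, meta to a methyl group and para to a fluoro group, the change from pyrimidin-2-yl to pyridin-2-yl is not silent: in the Mus musculus assay it gives a 6.0-fold lower unbound fraction from compound 2 to compound 3 (0.78 log units; beyond the scatter), although both compounds already lie close to full binding. The two groups have the same number of heavy atoms and differ only in one ring nitrogen exchanged for carbon, so this single ring atom accompanies the whole step. The same swap also shows in a physicochemical assay for solubility, read by nephelometry, in phosphate buffer, measured as kinetic solubility, at pH 6.5 (a lower number here means a less soluble compound, a higher number a more soluble compound), where compound 2 gives 50 ug/mL and compound 3 gives 6.3 ug/mL. This gap lies beyond the scatter: the measured solubility of compound 2, 50 ug/mL, and of compound 3, 6.3 ug/mL, a 7.9-fold lower number (0.90 log units; beyond the scatter)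

This one pair cannot tell whether the two shifts share a cause, or whether either would recur on the core of compound 1. It also leaves open how binding and solubility would respond to an amine on the pyridin-2-yl ring, or to a carboxylic acid at this position.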